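Working notes: cytotoxicity across the shared-core amides

This account rests on a few compounds, and the source may have more. Where it says the series, first, only, none or still open, it means among the compounds named here.

Compound 1 `COc1ccc(C(=O)Nc2cc3nc(C4CCCCC4)[nH]c3cc2N(C)C)cc1`: in an ADME assay on Vero cells (Chlorocebus sabaeus) for cytotoxicity, read by resazurin assay, with a stated time of 3 days (a lower number here means a stronger inhibitor, a higher number a weaker inhibitor), compound 1 gives > 100 ug/mL, a limit of the assay.
Compound 2 `CCN(CC)c1cc2[nH]c(C3CCCCC3)nc2cc1NC(=O)c1ccc(OC(F)(F)F)cc1`: compound 2 gives > 100 ug/mL, again a limit.
Compound 3 `CN(C)c1cc2[nH]c(C3CCCCC3)nc2cc1NC(=O)c1ccc(OC(F)(F)F)cc1`: compound 3 gives > 100 ug/mL, also a limit.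

Compound 2 therefore stands at the ceiling of the numbers shown, where all three values sit: the limit of > 100 ug/mL in this assay, at which 3 of the 3 values shown sit. The two measured steps, a step that the two limits leave unreadable from compound 1 to compound 3 and a step that the two limits leave unreadable from compound 2 to compound 3, are both unreadable, since each runs from one limit to another.

Compound 4 `CCOc1ccc(C(=O)Nc2cc3nc(C4CCCCC4)[nH]c3cc2N(CC)CC)cc1` differs from compound 2 by ethyl in place of trifluoromethyl on an oxygen on an aromatic ring. The step from compound 1 to compound 3 touches the same oxygen, but its size is unreadable, so no direction can be taken from it. With every value to date at the limit, compound 4 is expected to give 100 ug/mL, within 60 ug/mL to 200 ug/mL. The expected step is a number no higher from compound 2 to compound 4 (the limit leaves the size open), most likely ending at a limit again.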

Compound 4, half-maximal inhibitory concentration: > 100 ug/mL
Compound 4: no number, only a limit (the forecaster's own chance of this, stated with the estimate: 85%); the middle value sits exactly at the limit.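

In this assay compound 2 and compound 4 both stand only at a limit, so no new step can be read between them. The compounds shown leave open whether any change on the shared core would give a number rather than a limit.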